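This account rests on a few compounds, and the source may have more. Where it says the series, first, only, none or still open, it means among the compounds named here.

Compound 1 `CCOc1cc(=O)oc2cc(OCc3cccc(Br)c3)ccc12`: 2.5%
Compound 2 `CN(C)C(=O)COc1cc(=O)oc2cc(OCc3cccc(Cl)c3)ccc12`: 10%

Both numbers come from an assay on isolated protein (strain Sprague-Dawley) for inhibition of Amine oxidase [flavin-containing] A (Rattus norvegicus), read by spectrophotometry, with a stated time of 5 min, tested at 10 uM; a lower number here means less inhibition, a higher number more inhibition at the concentration tested (going by the name of the read-out). Compound 2 gives 10% and compound 1 gives 2.5%; the two lie within the scatter of each other, so compound 2 stands apart from nothing. For the measured compounds named here, no pair differing in one place has been measured, so no single change has a known size.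

Compound 3 `O=C(O)c1cc(=O)oc2cc(OCc3cccc(Cl)c3)ccc12` carries carboxy in place of (dimethylcarbamoyl)methoxy on an aromatic carbon. A step of a number 2 percentage points lower from compound 2 to compound 3 (within the scatter) is expected, none beyond the scatter, because compound 2 gives 10% and compound 1 gives 2.5%. Compound 3 is estimated at 8%, range 0% to 25%.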

Compound 3, a percentage reported as inhibition, at one concentration (the size of the read-out at that concentration, not a potency): 0%
Beside the measured number, compound 3's estimate is 8 percentage points above it; the measured number falls inside the stated range.
By their numbers in this assay, from the lowest: compounds 3, 1 and 2 (each within the scatter of the next).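

In this assay the first single change can now be read: carboxy in place of (dimethylcarbamoyl)methoxy on an aromatic carbon, opposite the ring oxygen, gives a number 10 percentage points lower from compound 2 to compound 3 (within the scatter) and so does not separate the two groups at this position. This holds even though the entering group has fewer heavy atoms and adds a hydrogen-bond donor. No measurement on hand explains the result.

Still open is whether an amine, a methyl ester or a longer chain at this position would give inhibition beyond the scatter of these compounds.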